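A few compounds are considered here, and "the series" means these few. Any claim that something is new, unique, unknown or untested is made for them only; others in the source may bear on it.

Measured so far in a functional assay on NCI-H522 cells (Homo sapiens) for cytotoxicity, read by sulforhodamine B assay, with a stated time of 48 h, tested at 0.1 uM; a higher number here means a weaker effect of the compound at the concentration tested, a lower number a stronger effect: compound 1 `COc1cc(-c2cc(/C=C/C(=O)c3ccc(Cl)c(Cl)c3)[nH]n2)cc(OC)c1OC` gives 89%; compound 2 `COc1ccc(-c2cc(/C=C/C(=O)c3ccc(N)cc3)[nH]n2)cc1OC` gives 95%; compound 3 `COc1ccc(-c2cc(/C=C/C(=O)c3cc(OC)c(OC)c(OC)c3)[nH]n2)cc1OC` gives 86%.

Compound 1 stands second highest of the three numbers. Its nearest neighbour is compound 3, whose value lies within the scatter of compound 1, and its furthest is compound 2, also within the scatter. Among the measured compounds shown here, no pair of measured compounds differs in only one place, so no single step is known.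

Compound 4 `COc1cc(-c2cc(/C=C/C(=O)c3ccc(F)c(F)c3)[nH]n2)cc(OC)c1OC` has not yet been measured. It differs from compound 1 in one place: 3,4-difluorophenyl in place of 3,4-dichlorophenyl on a carbonyl carbon. For the measured compounds named here, none of the measured compounds shows what this exchange does. In this assay the step is expected to be a number 1 percentage points higher from compound 1 to compound 4 (within the scatter), not beyond the scatter in either direction. Compound 4 is estimated at 90%, with a range from 80% to 100%.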

Compound 4, a percentage reported as activity, at one concentration (the size of the read-out at that concentration, not a potency): 99%
Estimate against measurement, compound 4: 9 percentage points below; the measured number falls inside the stated range.
By their numbers in this assay, from the lowest: compounds 3, 1, 2 and 4 (each within the scatter of the next, the first and the last beyond it).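

Among the compounds shown here, on the carbonyl carbon, 3,4-difluorophenyl in place of 3,4-dichlorophenyl gives in this assay a number 10 percentage points higher from compound 1 to compound 4 (within the scatter), the first single step that can be read. At the concentration tested, this assay therefore does not separate these two groups at this position. Nothing available gives a reason for this result.

As far as these compounds go, whether a carboxylic acid, a morpholine or a plain phenyl in place of either group on this carbonyl carbon would give a step beyond the scatter remains open. So does whether this exchange gives a similar step on other cores.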